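The compounds below may be only part of what the source reports. "The series", "measured", "known", "first", "only" and "open" are said of these compounds alone.

Measured in a functional assay on MGC-803 cells (Homo sapiens) for antiproliferative activity, read by MTT assay, with a stated time of 72 h; on this read-out higher numbers stand for weaker inhibition and lower numbers for stronger inhibition:
Compound 1 `Cc1ccccc1-n1nc(-c2ccccc2)nc1CNc1ccc(C(=O)NO)cc1`: 12300 nM
Compound 2 `O=C(NO)c1ccc(NCc2nc(-c3cccc(Cl)c3)nn2-c2ccccc2)cc1`: 5760 nM

Of these two, compound 2 has the lower number, at 5760 nM, and so shows the stronger inhibition. Its gap to compound 1, at 12300 nM, lies beyond the usual scatter. The two differ in more than one place, so the gap cannot be tied to any single change.

Compound 3 `O=C(NO)c1ccc(NCc2nc(-c3cc4ccccc4s3)nn2-c2ccccc2)cc1`, not yet measured, keeps the rest of compound 2 and changes one group: 1-benzothiophen-2-yl in place of 3-chlorophenyl on an aromatic carbon. In words, 1-benzothiophen-2-yl stands in place of 3-chlorophenyl on an aromatic carbon of a five-membered aromatic ring with 3 nitrogen. For the measured compounds named here, no measured pair shows what a change at this place does, so the expectation is only tentative. The starting point is compound 2 at 5760 nM, and a modest shift towards a lower number is expected in this assay, close to the edge of the scatter. Expressed as a step, the estimate is a 1.4-fold lower number from compound 2 to compound 3 (0.16 log units; within the scatter). For compound 3 the expected value is 4000 nM, with an estimated range from 1200 nM to 13000 nM.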

Compound 3, half-maximal inhibitory concentration: 6110 nM
For compound 3 the middle estimate is 1.5-fold (0.18 log units) below the measured one, and the stated range covers the measured number.
By their numbers in this assay, from the lowest: compounds 2, 3 and 1 (each within the scatter of the next, the first and the last beyond it).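

In this assay, for the compounds shown here, putting 1-benzothiophen-2-yl in place of 3-chlorophenyl gives a 1.1-fold higher number from compound 2 to compound 3 (0.03 log units; within the scatter), and this is the first single change read at this aromatic carbon of the five-membered aromatic ring with 3 nitrogen. The step shows that, at this place, a group of two aromatic rings containing sulfur and a single chlorine-bearing aromatic ring leave compound 2 and compound 3 indistinguishable in this assay, even though the entering group is the larger by heavy atoms and adds a hydrogen-bond acceptor by the count. Nothing among the available findings offers an explanation for this result.

The compounds shown cover only aromatic groups at this position, so it remains open whether an amine, a carboxylic acid or a short alkyl chain on the same carbon would keep the number in this range. Going by these compounds, it also remains open whether the same exchange would give a similar result with a group other than the phenyl group on the neighbouring ring atom, or with a different group in place of the hydroxamic acid.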